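The source may hold more compounds than are shown below. What is called first, only, known or untested is meant among the compounds shown, and "the series" means these compounds.

Two compounds have been measured so far, with the values from a functional assay on Jurkat cells (Homo sapiens) for antiproliferative activity, read by MTT assay, with a stated time of 48 h (on this read-out higher numbers stand for weaker inhibition and lower numbers for stronger inhibition), as follows

compound 1 `O=C(/C=C/c1ccc(Cn2cc(Nc3ncc(Cl)c(Nc4ccc(F)cc4)n3)cn2)cc1)NO` at 150 nM
compound 2 `CNc1nc(Nc2cnn(CCCCCCC(=O)NO)c2)ncc1Cl` at 70 nM

In this assay compound 2 stands at 70 nM and holds the lower of the two numbers, which makes it the stronger inhibitor of the pair. Its gap to compound 1 lies beyond the usual scatter. The next compound to be tested is compound 3 `O=C(CCCCCCn1cc(Nc2ncc(Cl)c(NC3CC3)n2)cn1)NO`, which differs from compound 2 at a single place (cyclopropyl in place of methyl on a nitrogen on an aromatic ring), with cyclopropyl in place of methyl on a nitrogen on an aromatic ring. Among the compounds with values here, the data hold no measured pair that isolates this change. Within the data shown here, compound 1 and compound 2 differ in more than one place, so compound 1 at 150 nM offers no step to carry over. The expectation therefore stays modest, with no change beyond the scatter and no firm direction. The estimated change is a 1.2-fold lower number from compound 2 to compound 3 (0.07 log units; within the scatter) and is expected to remain small. For compound 3 the estimated value in this assay is 60 nM (expected range 25 nM to 150 nM).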

Compound 3, half-maximal inhibitory concentration: 50 nM
Estimate against measurement, compound 3: 1.2-fold (0.08 log units) above; the range from low to high includes it.
By their numbers in this assay, from the lowest: compounds 3 and 2 (each within the scatter of the next); then compound 1.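

In this assay, within the data shown here, this pair is the first to isolate the position, and cyclopropyl in place of methyl on a nitrogen on an aromatic ring gives a 1.4-fold lower number from compound 2 to compound 3 (0.15 log units; within the scatter). Going from methylamino to cyclopropylamino thus adds two heavy atoms and a three-membered non-aromatic ring, yet compound 3 stays within the scatter of compound 2, so on this single pair the position accepts the cyclopropyl group without a change that can be told from assay noise. No measurement at hand bears on the reason for this result.

Going by these compounds, it remains open whether a hydrogen, an ethyl, an isopropyl or a cyclobutyl group on this nitrogen would also stay within the scatter, or whether a phenyl group or a group carrying an amine would move the number clearly. On these data alone, it is also open whether the same step would hold on a shorter or longer chain, since compound 1 differs from the others in more than one place and cannot speak to this.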